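Moving the acetyl group around the anilino ring

A few compounds are considered here, and "the series" means these few. Any claim that something is new, unique, unknown or untested is made for them only; others in the source may bear on it.

Measured compounds:
- compound 1 `CC(=O)c1cccc(Nc2ccnc(SCC(=O)c3ccc(-c4ccccc4)cc3)n2)c1`: 24%
- compound 2 `CC(=O)c1cccc(Nc2ccnc(SCC(=O)c3ccc(C(F)(F)F)cc3)n2)c1`: 29%
- compound 3 `CCOC(=O)c1ccc(Nc2ccnc(SCC(=O)c3ccc(C#N)cc3)n2)cc1`: 61%

In a functional assay on UACC-62 cells (Homo sapiens) for inhibition, read by sulforhodamine B assay, with a stated time of 48 h, tested at 10 uM (a higher number here means more inhibition of growth at the concentration tested, a lower number less inhibition of growth), compound 1 gives the lowest of the three numbers. Its nearest neighbour is compound 2, reached by a number 5 percentage points higher from compound 1 to compound 2 (within the scatter), a change at the far end of the molecule. For the measured compounds named here, compound 3 lies furthest away, with a value beyond the scatter from compound 1, but it differs in two places at once, so no single step can be drawn from it.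

Compound 4 `CC(=O)c1ccc(Nc2ccnc(SCC(=O)c3ccc(-c4ccccc4)cc3)n2)cc1` differs from compound 1 by 4-acetylphenyl in place of 3-acetylphenyl on a nitrogen on an aromatic ring. Going by the values given here, none of the measured steps changes the position of a group on this ring, so no direct guide exists. The expected step is a number 6 percentage points higher from compound 1 to compound 4 (within the scatter), within the scatter. Compound 4 is therefore estimated at 30%, in the range 10% to 55%.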

Compound 4, percent growth inhibition at one concentration: 20%
The estimate for compound 4 lay 10 percentage points above the measured number; the range from low to high includes it.
By their numbers in this assay, from the lowest: compounds 4, 1 and 2 (each within the scatter of the next); then compound 3.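

In this assay, swapping 3-acetylphenyl for 4-acetylphenyl on the nitrogen gives a number 4 percentage points lower from compound 1 to compound 4 (within the scatter). This is the first step shown that changes where a group sits on this ring, and with phenyl kept at the far end of the molecule, the two acetyl placements cannot be told apart. No other measurement here bears on this result. From the compounds shown here alone, it remains open whether the two placements would also match with trifluoromethyl at the far end, as in compound 2. Also open, going by these compounds, is how a carboxylic acid or an amine in place of the acetyl would read on this ring.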